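Swapping Thiophen-2-yl for Pentyl at the Carbonyl Carbon

The compounds below may be only part of what the source reports. "The series", "measured", "known", "first", "only" and "open" are said of these compounds alone.

In an ADME assay on U2OS cells (Homo sapiens) for cytotoxicity (a higher number here means that more compound is tolerated, a lower number that less compound is tolerated), compound 1 `O=C(N/N=C/c1ccc([N+](=O)[O-])o1)c1cccs1` gives 57200 nM, and compound 3 `CCCCNc1ccc(C(=O)N/N=C/c2ccc([N+](=O)[O-])o2)cc1` gives a lower 12000 nM. Compound 1 therefore holds the higher of the two actual numbers. Compound 2 `CCCCCCCCc1ccc(C(=O)N/N=C/c2ccc([N+](=O)[O-])o2)cc1` stands at > 200000 nM, which is a limit of the assay and not a number.

Compound 4 `CCCCCC(=O)N/N=C/c1ccc([N+](=O)[O-])o1` has pentyl in place of thiophen-2-yl on a carbonyl carbon. Going by the values given here, only one measured step offers any guide: an at least 16-fold lower number from compound 2 to compound 3 (1.22 log units; beyond the scatter), with butylamino in place of octyl on an aromatic carbon. That step is large, but it starts from a limit and occurs on an aromatic carbon rather than a carbonyl carbon, so it bears on this change only loosely. Among the compounds with values here, no measured step covers this exact swap, so the expectation stays anchored on compound 1 at 57200 nM, and no change beyond the scatter is expected in this assay. The expected outcome is a 1.0-fold higher number from compound 1 to compound 4 (0.02 log units; within the scatter). For compound 4 the estimate is 60000 nM, with an expected range of 18000 nM to 200000 nM.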

Compound 4, half-maximal cytotoxic concentration: 19300 nM
The estimate for compound 4 lay 3.1-fold (0.49 log units) above the measured number; the measured number falls inside the stated range.
By their numbers in this assay, from the lowest: compounds 3 and 4 (each within the scatter of the next); then compound 1. At a limit, above all of these: compound 2.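

At the carbonyl carbon the group does matter: pentyl in place of thiophen-2-yl gives a 3.0-fold lower number from compound 1 to compound 4 (0.47 log units; beyond the scatter) in this assay, a modest step but a real one. Going by these compounds alone, this is the first measured step at this position, as the only earlier step lay on an aromatic carbon, and it shows that two groups of 5 heavy atoms each are not interchangeable here, with the open chain tolerated less than the five-membered aromatic ring. Nothing among the measurements shown accounts for this difference.

On these data alone, it remains open whether the lower number goes with the loss of the ring or with the pentyl chain itself. A cyclopentyl ring, a phenyl ring, or a shorter or longer alkyl chain on the same carbonyl carbon would separate these two readings.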